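This account rests on a few compounds, and the source may have more. Where it says the series, first, only, none or still open, it means among the compounds named here.

The three measured compounds share one core and differ only in the group on an aromatic carbon of the five-membered ring. Compound 1 `C#C[C@@]1(O)[C@@H](CO)O[C@@H](n2cc(F)c3c(N)ncnc32)[C@@H]1O` carries fluoro there; in a functional assay on HeLa cells (Homo sapiens) for antiproliferative activity, read by cell counting, with a stated time of 72 h (a higher number here means a weaker inhibitor, a lower number a stronger inhibitor), compound 1 gives 150 nM. Compound 2 `C#C[C@@]1(O)[C@@H](CO)O[C@@H](n2cc(Cl)c3c(N)ncnc32)[C@@H]1O` carries chloro, and in this assay compound 2 gives 51 nM. Compound 3 `C#C[C@@]1(O)[C@@H](CO)O[C@@H](n2cc(I)c3c(N)ncnc32)[C@@H]1O` carries iodo, and in this assay compound 3 gives 180 nM, the highest number of the three; its gap to compound 1 is within the scatter, while the step of a 3.5-fold higher number from compound 2 to compound 3 (0.55 log units; beyond the scatter) lies beyond it, as does a 2.9-fold lower number from compound 1 to compound 2 (0.47 log units; beyond the scatter).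

Compound 4 `C#C[C@@]1(O)[C@@H](CO)O[C@@H](n2cc(-c3ccco3)c3c(N)ncnc32)[C@@H]1O` arises from compound 3 by one change: furan-2-yl in place of iodo on an aromatic carbon. Among the compounds with values here, none of the measured steps swaps a halogen for a ring, so they bear on this change only loosely. They show that the three halogens spread this assay over a modest range, with chloro lowest and fluoro and iodo close together. Compound 4 is therefore expected to land near compound 3, and the estimated step of a 1.4-fold higher number from compound 3 to compound 4 (0.14 log units; within the scatter) is taken as small, with wide uncertainty in either direction. For compound 4 the number in this assay is estimated at 250 nM, within a range from 50 nM to 1500 nM.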

Compound 4, half-maximal inhibitory concentration: 14000 nM
Compound 4: the middle estimate sits 56-fold (1.75 log units) below what was measured, and the stated range ends below it.
By their numbers in this assay, from the lowest: compound 2; then compounds 1 and 3 (each within the scatter of the next); then compound 4.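

Set against the modest spread among the halogens in this assay, furan-2-yl at this position brings a change of another order: a 78-fold higher number from compound 3 to compound 4 (1.89 log units; beyond the scatter) is a large step, and a 270-fold higher number from compound 2 to compound 4 (2.44 log units; beyond the scatter) and a 93-fold higher number from compound 1 to compound 4 (1.97 log units; beyond the scatter) are large as well. This aromatic carbon, two ring bonds from the ring nitrogen, therefore keeps the number within a narrow band across fluoro, chloro and iodo, yet the exchange of a single iodine atom for a five-membered aromatic ring of 5 heavy atoms makes compound 4 the weakest of the four. Nothing among the data shown accounts for this loss of activity.

On these data alone, whether the loss follows any aromatic ring at this carbon or belongs to furan-2-yl alone stays open, a question that phenyl or thiophen-2-yl would address. Also open, as far as these compounds go, is how the number responds to small non-halogen groups such as methyl, ethynyl or an amine, which would show whether the halogens' narrow band extends beyond them.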